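Ring-opening of the piperidinyl ether in a sulfonamide series

The compounds below may be only part of what the source reports. "The series", "measured", "known", "first", "only" and "open" are said of these compounds alone.

Of the compounds shown here, two of the shared core have been measured in a functional assay on HCT-116 cells (Homo sapiens) for cytotoxicity; on this read-out lower numbers stand for an effect already at smaller amounts and higher numbers for an effect only at larger amounts of compound. Compound 1 `COc1ccc(S(=O)(=O)Nc2ccc(C(=O)CSC(C)=O)cn2)cc1` gives 540 nM in this assay. Within the data shown here, compound 2 `CC(=O)SCC(=O)c1ccc(NS(=O)(=O)c2ccc(OC3CCN(C)CC3)cc2)nc1` gives 180 nM in this assay, the lower of the two numbers; the only other compound, compound 1, sits a 3.0-fold lower number from compound 1 to compound 2 (0.48 log units; beyond the scatter) away from it. Among the measured compounds shown here, that single step, 1-methylpiperidin-4-yl in place of methyl on an oxygen on an aromatic ring, is the one measured change so far.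

Compound 3 `CC(=O)SCC(=O)c1ccc(NS(=O)(=O)c2ccc(OCCCCN(C)C)cc2)nc1` is not yet measured. It differs from compound 2 by 4-(dimethylamino)butyl in place of 1-methylpiperidin-4-yl on an oxygen on an aromatic ring. The group that leaves and the group that enters match in heavy-atom count and in the number of hydrogen-bond acceptors; the ring is opened into a chain. For the measured compounds named here, no measured step tests such a ring-to-chain change; the step from compound 1 to compound 2 only shows that a larger group with a nitrogen at this oxygen is tolerated. On that basis the step of a 1.1-fold higher number from compound 2 to compound 3 (0.05 log units; within the scatter) is expected to stay within the scatter. Compound 3 is thus estimated at 200 nM in this assay, with a range from 70 nM to 550 nM.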

Compound 3, half-maximal effective concentration: 280 nM
The estimate for compound 3 lay 1.4-fold (0.15 log units) below the measured number; measured number inside the range.
By their numbers in this assay, from the lowest: compounds 2, 3 and 1 (each within the scatter of the next, the first and the last beyond it).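

In this assay, opening the 1-methylpiperidin-4-yl group into the 4-(dimethylamino)butyl chain on this oxygen gives a 1.6-fold higher number from compound 2 to compound 3 (0.19 log units; within the scatter), so within this pair the intact ring is not needed to stay within the scatter of compound 2, at the same heavy-atom count. The chain, however, does not separate clearly from the methyl group: the change to the chain gives a 1.9-fold lower number from compound 1 to compound 3 (0.29 log units; within the scatter), whereas the change to the ring gave a 3.0-fold lower number from compound 1 to compound 2 (0.48 log units; beyond the scatter), so only the ring stands clear of compound 1, and compound 3 sits within the scatter of both neighbours. No available data explain either step.

The compounds shown leave open whether the amine nitrogen itself matters at this oxygen, a question that a plain butyl chain or a chain ending in a carboxylic acid would address. They also leave open how the number depends on chain length, which a shorter 2-(dimethylamino)ethyl chain or a longer 6-(dimethylamino)hexyl chain would test.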